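Chain homologation on two methoxyphenyl alkylamide cores

A few compounds are considered here, and "the series" means these few. Any claim that something is new, unique, unknown or untested is made for them only; others in the source may bear on it.

Compound 1 `CCC(=O)NCCCc1ccccc1OC` is the propanoyl amide on the shorter-chain core; in an assay for binding affinity to melatonin receptor (Gallus gallus) (on this read-out higher numbers stand for weaker inhibition and lower numbers for stronger inhibition), compound 1 gives 374 nM. Compound 2 `CCCC(=O)NCCCc1ccccc1OC` differs from it by methyl in place of hydrogen on a saturated chain carbon, two bonds along the chain from a carbonyl carbon. In this assay compound 2 gives 442 nM, which makes the step of a 1.2-fold higher number from compound 1 to compound 2 (0.07 log units; within the scatter). Compound 3 `CCCC(=O)NCCCCc1ccc(OC)cc1` is built on the other core; the difference between the two cores is not broken down here. In this assay compound 3 gives 822 nM; set against compound 2 this is a higher number that stays within the scatter, and set against compound 1 a higher number that lies beyond it.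

Compound 4 `CCCCC(=O)NCCCCc1ccc(OC)cc1` is the homologue of compound 3 and is not yet measured; it differs from compound 3 by methyl in place of hydrogen on a saturated chain carbon, three bonds along the chain from a carbonyl carbon. This is the same kind of change as that from compound 1 to compound 2, not the same change: there the methyl enters two bonds along the chain from a carbonyl carbon, here three bonds along the chain from a carbonyl carbon, and the core is the other one. Among the compounds with values here, with only a single prior example, the expectation is a step of about a 1.2-fold higher number from compound 3 to compound 4 (0.06 log units; within the scatter), because a 1.2-fold higher number from compound 1 to compound 2 (0.07 log units; within the scatter) stayed within the scatter as the one measured instance of this kind of change. On that basis compound 4 is estimated at 950 nM in this assay, with a range expected from 450 nM to 2000 nM.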

Compound 4, inhibition constant: 7000 nM
For compound 4 the middle estimate is 7.4-fold (0.87 log units) below the measured one; measured number above the stated range.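

In this assay the step on the core of compound 3 reads an 8.5-fold higher number from compound 3 to compound 4 (0.93 log units; beyond the scatter), so a small step on one core gave no safe guide to the same kind of change on the other, and the two steps cannot be treated as one transferable increment in this series: the same change on two cores in this assay, a 1.2-fold higher number (0.07 log units; within the scatter) from compound 1 to compound 2 and an 8.5-fold higher number (0.93 log units; beyond the scatter) from compound 3 to compound 4, 7.2-fold (0.86 log units) apart, beyond the scatter of two such steps

What this does not show is which difference matters, since the two steps differ in two places at once: the core, and the place where the methyl enters, two bonds along the chain from a carbonyl carbon in one case and three bonds along it in the other. Within the data shown here, with only one step on each core, the data also give no trend with chain length on either core, and a sharp limit on chain length on the core of compound 3 is no more than one possible reading of a single step.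

Open, as far as these compounds go, is how a pentanoyl amide on the core of compound 1 would behave, a match that would separate the effect of the core from that of the place of the methyl. Also open, from the compounds shown here alone, is whether a longer chain such as hexanoyl, or a shorter one such as acetyl, would extend the picture on either core.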